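The compounds below may be only part of what the source reports. "The series", "measured", "known", "first", "only" and "open" are said of these compounds alone.

- Compound 1 `COc1ccc2c(c1)nc(/C=C/C(=O)/C=C/c1ccc(O)c(OC)c1)n2C`: 3900 nM
- Compound 2 `COc1ccc(/C=C/C(=O)/C=C/c2nc3cc(C)ccc3n2C)cc1O`: 3600 nM

Both compounds were tested in a functional assay on MCF7 cells (Homo sapiens) for cytotoxicity, read by MTT assay, with a stated time of 48 h; on this read-out higher numbers stand for weaker inhibition and lower numbers for stronger inhibition. There, compound 2 gives 3600 nM and compound 1 gives 3900 nM. These two numbers lie within the usual scatter of repeated measurements, so compound 2 stands level with compound 1, and neither can be ranked above the other.

Compound 3 `COc1ccc2c(c1)nc(/C=C/C(=O)/C=C/c1ccc(OC)c(O)c1)n2C` has not yet been measured. It differs from compound 2 in one place: methoxy stands in place of methyl on an aromatic carbon of a six-membered aromatic ring of carbon only, part of a fused or bridged system of two rings (methoxy in place of methyl on an aromatic carbon).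

Among the compounds with values here, no measured pair shows this exact change on its own, so the evidence for it is thin. Within the data shown here, the only guide is that the two measured compounds sit close together in this assay, which gives no reason to expect a large shift. The step of a 1.0-fold higher number from compound 2 to compound 3 (0.01 log units; within the scatter) is therefore expected to stay within the scatter, with no clear direction. For compound 3 the estimated value is 3700 nM, with an expected range from 1600 nM to 8500 nM.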

Compound 3, half-maximal inhibitory concentration: 3700 nM
Compound 3: middle estimate and measured number agree at the digits printed; the range from low to high includes it.
By their numbers in this assay, from the lowest: compounds 2, 3 and 1 (each within the scatter of the next).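

In this assay, within the data shown here, methoxy in place of methyl on the aromatic carbon of the fused ring system gives a 1.0-fold higher number from compound 2 to compound 3 (0.01 log units; within the scatter) so at this position, adding one heavy atom and one hydrogen-bond acceptor produces no step that can be told apart from repeat-measurement noise. Compound 3 also adds a second one-place comparison, 3-hydroxy-4-methoxyphenyl in place of 4-hydroxy-3-methoxyphenyl on the double-bonded chain carbon, and this too gives a step within the scatter: a 1.1-fold lower number from compound 1 to compound 3 (0.02 log units; within the scatter) and so the arrangement of hydroxy and methoxy on that ring makes no readable difference in this pair. The data at hand offer no explanation for either result.

Methyl and methoxy are the only groups shown on the fused ring system, so it remains open whether an amine, a carboxylic acid or a longer chain such as butoxy there would leave the number within the scatter. On the other ring, both compounds carry one hydroxy and one methoxy, which leaves open what a ring with an amine or a carboxylic acid in place of the hydroxy would give.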